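A few compounds are considered here, and "the series" means these few. Any claim that something is new, unique, unknown or untested is made for them only; others in the source may bear on it.

Compounds measured so far:
compound 1 `COc1ccc(N/C(CCNC2=CC(=O)c3ccccc3C2=O)=N\S(=O)(=O)c2ccc(C)cc2)cc1` with 7590 nM
compound 2 `Cc1ccc(S(=O)(=O)/N=C(/CCNC2=CC(=O)c3ccccc3C2=O)Nc2ccc(Cl)cc2)cc1` with 13400 nM
compound 3 `Cc1ccc(S(=O)(=O)/N=C(/CCNC2=CC(=O)c3ccccc3C2=O)Nc2ccccc2I)cc1` with 19100 nM

In a functional assay on HeLa cells (Homo sapiens) for cytotoxicity, read by MTT assay, with a stated time of 48 h (on this read-out lower numbers stand for stronger inhibition and higher numbers for weaker inhibition), compound 3 gives the highest of the three numbers. Its nearest neighbour is compound 2, which in this assay gives 13400 nM, and the two differ only by a 1.4-fold higher number from compound 2 to compound 3 (0.15 log units; within the scatter), a gap within the scatter. Compound 1 gives 7590 nM in this assay, and the step of a 2.5-fold higher number from compound 1 to compound 3 (0.40 log units; beyond the scatter) is beyond the scatter, though modest. The step of a 1.8-fold higher number from compound 1 to compound 2 (0.25 log units; within the scatter) is within the scatter.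

Compound 4 `Cc1ccc(S(=O)(=O)/N=C(\N)CCNC2=CC(=O)c3ccccc3C2=O)cc1` is not yet measured. Its difference from compound 3 is hydrogen in place of 2-iodophenyl on an amine nitrogen. Among the compounds with values here, the two steps that bear on it, a 2.5-fold higher number from compound 1 to compound 3 (0.40 log units; beyond the scatter) and a 1.4-fold higher number from compound 2 to compound 3 (0.15 log units; within the scatter), only exchange one aryl group for another on the amine nitrogen; none of the measured steps removes the aryl group altogether, so the present change lies outside what the three compounds have probed. All three numbers fall in a narrow span, and the variations among the aryl groups moved them little. With the 2-iodophenyl gone entirely, a somewhat larger shift is expected, more likely toward a higher number, and the estimated step is a 1.6-fold higher number from compound 3 to compound 4 (0.20 log units; within the scatter). For compound 4 in this assay the expected value is 30000 nM, within a range from 10000 nM to 90000 nM.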

Compound 4, half-maximal inhibitory concentration: 24600 nM
Compound 4: the middle estimate sits 1.2-fold (0.09 log units) above what was measured, and the stated range covers the measured number.
By their numbers in this assay, from the lowest: compounds 1, 2, 3 and 4 (each within the scatter of the next, the first and the last beyond it).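

In this assay, taking the aryl group off the amine nitrogen altogether, so that seven heavy atoms leave and only a hydrogen enters, still gives a step within the scatter against the 2-iodophenyl compound, a 1.3-fold higher number from compound 3 to compound 4 (0.11 log units; within the scatter), and against the 4-chlorophenyl compound, a 1.8-fold higher number from compound 2 to compound 4 (0.26 log units; within the scatter). Compound 1 goes against this picture, since the step from the 4-methoxyphenyl compound, a 3.2-fold higher number from compound 1 to compound 4 (0.51 log units; beyond the scatter), lies beyond the scatter, though it is modest, so the aryl group on this nitrogen makes a measurable difference only in that comparison. Nothing available on these compounds explains this result.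

The four compounds leave open whether a methyl group, a benzyl group or a longer alkyl chain on this amine nitrogen would stay in the same span or move away from it, and whether a 4-hydroxyphenyl or 4-dimethylaminophenyl group would extend the small gain seen with 4-methoxyphenyl. On these data alone, the rest of the structure is shared by all four, so what it contributes to the numbers in this assay also remains open.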